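Sulfonyl aryl variation on a shared core, antiproliferative read-out

The compounds below may be only part of what the source reports. "The series", "measured", "known", "first", "only" and "open" are said of these compounds alone.

Compound 3 `COc1ccc(S(=O)(=O)n2cc(/C=C/C(=O)c3ccncc3)c3ccccc32)cc1` gives only a limit in an ADME assay on HEK293 cells (Homo sapiens) for antiproliferative activity, read by MTT assay, with a stated time of 48 h; on this read-out lower numbers stand for stronger inhibition and higher numbers for weaker inhibition: compound 3 reads > 150000 nM. Compound 1 `CC(C)(C)c1ccc(S(=O)(=O)n2cc(/C=C/C(=O)c3ccncc3)c3ccccc32)cc1` likewise gives a limit of > 150000 nM in this assay. Compound 2 `O=C(/C=C/c1cn(S(=O)(=O)c2cccc3ccccc23)c2ccccc12)c1ccncc1` also gives a limit of > 150000 nM. All three thus sit at the same limit (the limit of > 150000 nM in this assay, at which 3 of the 3 values shown sit). The steps among them, a step that the two limits leave unreadable from compound 1 to compound 2, a step that the two limits leave unreadable from compound 1 to compound 3 and a step that the two limits leave unreadable from compound 2 to compound 3, cannot be read because of the limit of > 150000 nM in this assay, at which 3 of the 3 values shown sit. Compound 4 `O=C(/C=C/c1cn(S(=O)(=O)c2ccc(Cl)cc2Cl)c2ccccc12)c1ccncc1` differs from compound 3 by 2,4-dichlorophenyl in place of 4-methoxyphenyl on a sulfonyl sulfur. No measured step sizes an exchange of the aryl group on the sulfonyl sulfur, so no step beyond the scatter is expected in this assay. Compound 4 is expected to stay at the limit, the step that the limit leaves unreadable from compound 3 to compound 4 meaning no real change. Compound 4 is estimated at 200000 nM, within 80000 nM to 500000 nM.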

Compound 4, half-maximal inhibitory concentration: > 150000 nM
Compound 4: a limit, no number (the forecaster's own chance of this, stated with the estimate: 80%); the middle value is on the limit's open side.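

The steps from compound 1, compound 2 and compound 3 to compound 4 cannot be read, as all four compounds give only a limit: the limit of > 150000 nM in this assay, at which 4 of the 4 values shown sit.

Going by these compounds, whether any aryl group on the sulfonyl sulfur gives a readable value on the shared core remains open.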